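Bromo in Place of Methyl: Two Matched Pairs

The compounds below may be only part of what the source reports. "The series", "measured", "known", "first", "only" and "open" are said of these compounds alone.

Compound 1 `Cc1ccc(-c2nc(CNc3ccc(C(=O)NO)cc3)n(-c3ccccc3)n2)cc1` and compound 2 `O=C(NO)c1ccc(NCc2nc(-c3ccc(Br)cc3)nn2-c2ccccc2)cc1` differ in a single change, bromo in place of methyl on an aromatic carbon. In an assay on Sf9 cells for inhibition of protein deacetylase HDAC6 (Homo sapiens), read by fluorescence, with a stated time of 40 min, tested at 100 nM (a higher number here means more inhibition at the concentration tested (going by the name of the read-out), a lower number less inhibition), compound 1 gives 62.2%, while compound 2 gives 54.7%. The step between them, a number 7.5 percentage points lower from compound 1 to compound 2 (within the scatter), is small enough to sit within the usual scatter of repeated measurements, so it does not point to a real change.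

Compound 3 `Cc1ccc(-n2nc(-c3ccccc3)nc2CNc2ccc(C(=O)NO)cc2)cc1` is built from the same atoms as compound 1, joined differently; the difference between the two cores is not broken down here. In this assay compound 3 gives 60.7%.

Compound 4 `O=C(NO)c1ccc(NCc2nc(-c3ccccc3)nn2-c2ccc(Br)cc2)cc1` is not yet measured. It differs from compound 3 by the same change (bromo in place of methyl on an aromatic carbon), at a place described in the same words as before. Because the earlier step of a number 7.5 percentage points lower from compound 1 to compound 2 (within the scatter) stayed within the scatter, a step of similar size is expected here too, a number 7.7 percentage points lower from compound 3 to compound 4 (within the scatter). Compound 4 is therefore expected to give about 53%, with a likely range from 38% to 68%.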

Compound 4, a percentage reported as inhibition, at one concentration (the size of the read-out at that concentration, not a potency): 65.9%
Estimate against measurement, compound 4: 12.9 percentage points below; low and high end bracket the measured number.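

In this assay, the same swap on the second core gives a step that is a number 5.2 percentage points higher from compound 3 to compound 4 (within the scatter), so here too it does not point to a real change. Set side by side, the two steps do not differ by more than two such steps normally would: the same change on two cores in this assay, a number 7.5 percentage points lower (within the scatter) from compound 1 to compound 2 and a number 5.2 percentage points higher (within the scatter) from compound 3 to compound 4, 12.7 percentage points apart, within the scatter of two such steps. Going from 4-methylphenyl to 4-bromophenyl therefore leaves the reading within the scatter on both cores, and the fact that one step is lower and the other higher is no real reversal, but two pairs read at a single concentration cannot show how the change would behave on any other core.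

The compounds shown leave open whether a different group on the same aromatic carbon, such as a nitrile or a carboxylic acid, would move the reading beyond the scatter. They also leave open whether these compounds would separate at another test concentration.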